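Solubility notes: moving from compound 3 to compound 4

This account rests on a few compounds, and the source may have more. Where it says the series, first, only, none or still open, it means among the compounds named here.

Measured so far in a physicochemical assay for solubility, measured as kinetic solubility, at pH 7.4; a lower number here means a less soluble compound, a higher number a more soluble compound
- compound 1 `COc1cc(N2CCN(C(=O)N3CCN(C)CC3)CC2)ccc1Nc1nc(NC2CCCCC2)c2nc[nH]c2n1` gives 75000 nM
- compound 2 `COc1cc(N2CCN(C(=O)N3CCC(O)C3)CC2)ccc1Nc1nc(NC2CCCCC2)c2nc[nH]c2n1` gives 19000 nM
- compound 3 `COc1cc(N2CCC(C(=O)N3CCOCC3)CC2)ccc1Nc1nc(NC2CCCCC2)c2nc[nH]c2n1` gives 19000 nM

Compound 3 stands level with compound 2, the two sharing the lowest number of the three, and compound 1 has the higher number.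

The next compound is compound 4 `COc1cc(N2CCC(CC(=O)N3CCCC3)CC2)ccc1Nc1nc(NC2CCCCC2)c2nc[nH]c2n1`, which carries ((pyrrolidin-1-yl)carbonyl)methyl in place of (morpholin-4-yl)carbonyl on a saturated ring carbon. In full, ((pyrrolidin-1-yl)carbonyl)methyl in place of (morpholin-4-yl)carbonyl on a saturated ring carbon is the counted difference.

Within the data shown here, the only measured step in the set is a 3.9-fold lower number from compound 1 to compound 2 (0.60 log units; beyond the scatter), with 3-hydroxypyrrolidin-1-yl in place of 4-methylpiperazin-1-yl on a carbonyl carbon. Among the measured compounds shown here, that step involves other groups, and no measured pair shows the present change, so it serves as a guide to size only. The direction is a judgement from the structural change, not a measured precedent.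

For the measured compounds named here, a modest step toward a lower number is expected in this assay, no larger than the step from compound 1 to compound 2. The expected move is a 2.1-fold lower number from compound 3 to compound 4 (0.32 log units; beyond the scatter), and it may prove to lie close to the scatter. The estimate for compound 4 is 9000 nM, with an expected range of 3000 nM to 24000 nM as its span.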

Compound 4, solubility: 19000 nM
Estimate against measurement, compound 4: 2.1-fold (0.32 log units) below, within the range that was stated.
By their numbers in this assay, from the lowest: compounds 2, 3 and 4 (each within the scatter of the next); then compound 1.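

In this assay, among these compounds, ((pyrrolidin-1-yl)carbonyl)methyl in place of (morpholin-4-yl)carbonyl gives no change at the digits printed from compound 3 to compound 4 (within the scatter), which is the first measured pair at this saturated ring carbon, three ring bonds from the ring nitrogen. The step changes several things at once: the entering group has a five-membered ring and a methyl link to the ring carbon, while the leaving group has a six-membered ring with 2 hetero atoms and its carbonyl directly on that carbon, and this single pair records no separate contribution from any of them. No measured evidence bears on why the read-out holds across this exchange.

On these data alone, it remains open whether the ring exchange and the methyl link are each silent alone or offset one another, a question that (pyrrolidin-1-yl)carbonyl directly on the ring carbon or ((morpholin-4-yl)carbonyl)methyl would address. Also open, as far as these compounds go, is how this position responds to a group of a different type, such as a carboxylic acid, a dimethylamino group or a longer chain ending in a hydroxyl group.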